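This account rests on a few compounds, and the source may have more. Where it says the series, first, only, none or still open, it means among the compounds named here.

In a functional assay on HeLa cells (Homo sapiens) for antiproliferative activity, read by MTT assay, with a stated time of 48 h, in the presence of a further agent that is not named here (a higher number here means a weaker inhibitor of growth, a lower number a stronger inhibitor of growth), compound 1 `O=C(NOCc1ccccc1F)c1cn(-c2ccccc2)nc1-c1ccccc1` gives 11800 nM. In this assay compound 2 `COc1ccc(-c2nn(-c3ccccc3)cc2C(=O)NOCc2ccccc2)cc1` gives 2640 nM.

Compound 2 holds the lower of the two numbers, and compound 1 lies well beyond the scatter above it; as the two differ in more than one place, their gap is not read as a single step. Compound 3 `COc1ccc(-c2nn(-c3ccccc3)cc2C(=O)NOCc2ccccc2F)cc1` differs from compound 2 by fluoro in place of hydrogen on an aromatic carbon. Within the data shown here, no measured pair isolates this change, so compound 3 is expected to show only a small step of a 1.1-fold lower number from compound 2 to compound 3 (0.02 log units; within the scatter), within the scatter. Compound 3 is therefore estimated at 2500 nM, with a range from 900 nM to 7000 nM.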

Compound 3, concentration for 50% growth inhibition: 2900 nM
The estimate for compound 3 lay 1.2-fold (0.06 log units) below the measured number, within the range that was stated.
By their numbers in this assay, from the lowest: compounds 2 and 3 (each within the scatter of the next); then compound 1.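

In this assay there is a 1.1-fold higher number from compound 2 to compound 3 (0.04 log units; within the scatter) for fluoro in place of hydrogen on an aromatic carbon, so this change on the benzyl group leaves the number within the scatter. Among these compounds, with the 2-fluorobenzyl group shared, a 4.1-fold lower number from compound 1 to compound 3 (0.61 log units; beyond the scatter) goes with the added methoxy group, making methoxy, not fluoro, the one isolated change that moves the number beyond the scatter. Nothing available gives a reason for either step.

From the compounds shown here alone, whether the fluoro step would hold without the methoxy stays open. So does whether an amine or a carboxylic acid in place of the methoxy would shift the number.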